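Between Fluoro and Bromo: Estimating the Chloro Compound

A few compounds are considered here, and "the series" means these few. Any claim that something is new, unique, unknown or untested is made for them only; others in the source may bear on it.

Among the compounds with values here, in a functional assay on DU-145 cells (Homo sapiens) for cytotoxicity, read by trypan blue exclusion, with a stated time of 96 h (a lower number here means a stronger inhibitor, a higher number a weaker inhibitor), compound 1 (`COc1cc(OC)c(/C=C/S(=O)(=O)Cc2ccc(F)c(N)c2)c(OC)c1`) gives 2500 nM, while compound 2 (`COc1cc(OC)c(/C=C/S(=O)(=O)Cc2ccc(Br)c(N)c2)c(OC)c1`) gives 750 nM, the lower of the two numbers so far. The next compound to be measured is compound 3 (`COc1cc(OC)c(/C=C/S(=O)(=O)Cc2ccc(Cl)c(N)c2)c(OC)c1`), which has chloro in place of bromo on an aromatic carbon. Within the data shown here, only one measured step bears on this change, the exchange of fluoro for bromo on an aromatic carbon, a 3.3-fold lower number from compound 1 to compound 2 (0.52 log units; beyond the scatter), a modest step beyond the scatter. Among the measured compounds shown here, no chloro compound has yet been measured, so this single step is the only guide. Leaving bromo is expected to give a higher number in this assay, though a smaller change than that one step. The expected change is a 1.6-fold higher number from compound 2 to compound 3 (0.20 log units; within the scatter). For compound 3 the estimated value is 1200 nM, within an expected range of 600 nM to 2400 nM.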

Compound 3, half-maximal inhibitory concentration: 10 nM
Compound 3: middle estimate off by 120-fold (2.08 log units), on the high side, outside the stated range (below it).
By their numbers in this assay, from the lowest: compound 3; then compound 2; then compound 1.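

In this assay, the halogen on this aromatic carbon, ortho to an amino group and para to a large group, does not behave as a graded series: chloro does not fall between fluoro and bromo, with a 75-fold lower number from compound 2 to compound 3 (1.88 log units; beyond the scatter) and a 250-fold lower number from compound 1 to compound 3 (2.40 log units; beyond the scatter). The earlier pair showed only a modest step here, whereas these results show that exchanging one heavy atom at this position, with no ring, hydrogen-bond donor, hydrogen-bond acceptor or net charge entering or leaving, can move the number much further. No measurement at hand accounts for the result obtained with chloro.

The compounds shown leave open whether this large gain belongs to chloro alone or would also appear with a methyl or trifluoromethyl group on the same carbon. Going by these compounds, whether compound 3 would keep its low number with a hydroxyl group in place of the amino group also remains open.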